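Swapping iodine for a nitrile on the outer phenyl ring

The source may hold more compounds than are shown below. What is called first, only, known or untested is meant among the compounds shown, and "the series" means these compounds.

Compound 1 `N[C@@H](COP(=O)(O)OCCCOC(=O)CCc1ccccc1OCc1cccc(Oc2ccccc2Cl)c1)C(=O)O` gives 0.069 in an assay on cells for activation of probable G-protein coupled receptor 34 (Mus musculus), with a stated time of 1 h; on this read-out higher numbers stand for larger maximal responses and lower numbers for smaller maximal responses.
Compound 2 `N[C@@H](COP(=O)(O)OCCCOC(=O)CCc1ccccc1OCc1cccc(Oc2ccc(F)cc2)c1)C(=O)O` gives 0.66.
Compound 3 `N[C@@H](COP(=O)(O)OCCCOC(=O)CCc1ccccc1OCc1cccc(Oc2ccc(I)cc2)c1)C(=O)O` gives 0.82.

All three compounds share the same core and differ only in the halogen-bearing phenyl ring at the far end. Compound 3 stands highest of the three numbers: its nearest neighbour is compound 2, seen in the step a number 0.16 higher from compound 2 to compound 3 (beyond the scatter), and the furthest is compound 1, seen in a number 0.75 higher from compound 1 to compound 3 (beyond the scatter).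

Compound 4 `N#Cc1ccc(Oc2cccc(COc3ccccc3CCC(=O)OCCCOP(=O)(O)OC[C@H](N)C(=O)O)c2)cc1` is the next step from compound 3. The change is cyano in place of iodo on an aromatic carbon.

Among the measured compounds shown here, only one measured step touches the same place on the ring: a number 0.16 higher from compound 2 to compound 3 (beyond the scatter), a modest rise when one halogen replaced another. For the measured compounds named here, no measured step involves a cyano group, so there is no direct guide to it. Both compounds carrying a group para to the large oxygen-linked part, compound 2 and compound 3, gave large responses, while compound 1, with its chlorine elsewhere, gave a small one.

Compound 4 is therefore expected to stay in the higher range, with a step of about a number 0.20 lower from compound 3 to compound 4 (beyond the scatter) allowed for the lack of any cyano data. The estimate for compound 4 is 0.62, ranging from 0.3 to 0.9.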

Compound 4, intrinsic activity: the largest response reached, as a fraction of the reference agonist's: 0.041
Estimate against measurement, compound 4: 0.58 above; the measured number lies below the stated range.
By their numbers in this assay, from the lowest: compounds 4 and 1 (each within the scatter of the next); then compound 2; then compound 3.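

In this assay, putting cyano on this aromatic carbon gives a number 0.78 lower from compound 3 to compound 4 (beyond the scatter) and, measured against fluoro, a number 0.62 lower from compound 2 to compound 4 (beyond the scatter) in the maximal response. So the earlier link between a group para to a large group and a large response holds for iodo and fluoro, but compound 4 goes against it: what matters is which group sits there, not only that one does. Compound 4 also falls level with compound 1, which carries its chlorine on a different ring position, with a number 0.028 lower from compound 1 to compound 4 (within the scatter) so that these two cannot be told apart, and nothing available here explains why the nitrile behaves so differently from the two halogens.

The compounds shown leave open whether this collapse is special to the nitrile or extends to other groups at this place, such as an amine, a methyl group or a carboxylic acid. They also leave open whether chloro or bromo at this same place would keep the large response seen with fluoro and iodo.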